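The compounds below may be only part of what the source reports. "The series", "measured", "known", "first", "only" and "open" are said of these compounds alone.

Compound 2 `CCOC(=O)c1cnc(N2CCN(Cc3ccccc3C(=O)OC)CC2)nc1Oc1c(C)cc(-c2ccc(C#N)cc2)cc1C` stands, on the numbers shown, only at a limit. In an ADME assay on MT4 cells (Homo sapiens) for cytotoxicity, read by MTT assay, with a stated time of 4 days (a higher number here means that more compound is tolerated, a lower number that less compound is tolerated), compound 2 gives > 125000 nM, a limit of the assay rather than a number. For the measured compounds named here, compound 1 `CCOC(=O)c1cnc(N2CCN(Cc3ccc(F)cc3)CC2)nc1Oc1c(C)cc(-c2ccc(C#N)cc2)cc1C` is its one measured neighbour, differing at the saturated chain carbon bound to an amine nitrogen in a ring. In this assay compound 1 gives > 117000 nM, also a limit. The step that the two limits leave unreadable from compound 1 to compound 2 cannot be read because both values sit at limits, as the limit of > 117000 nM in this assay, at which 1 of the 2 values shown sits, and the limit of > 125000 nM in this assay, at which 1 of the 2 values shown sits, show.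

Compound 3 `CCOC(=O)c1cnc(N2CCN(Cc3cccc(Br)c3)CC2)nc1Oc1c(C)cc(-c2ccc(C#N)cc2)cc1C` awaits measurement. The change is 3-bromophenyl in place of 2-(methoxycarbonyl)phenyl on a saturated chain carbon bound to an amine nitrogen in a ring. The single measured step at this position is unreadable, so no size can be borrowed from it, and nothing shown points in either direction. Compound 3 is therefore expected to remain near the limits seen, at about 120000 nM, within 50000 nM to 250000 nM. That estimate corresponds to an expected step of an at least 1.0-fold lower number from compound 2 to compound 3 (0.01 log units; that floor lies within the scatter).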

Compound 3, half-maximal cytotoxic concentration: > 125000 nM
Compound 3 gave a limit, no number (the forecaster's own chance of this, stated with the estimate: 75%); middle value at least 1.0-fold (0.01 log units) from the limit.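

In this assay compound 3 gives > 125000 nM, a limit and not a number. No step among compound 1, compound 2 and compound 3 can be read, since all three values are limits: the limit of > 125000 nM in this assay, at which 2 of the 3 values shown sit.

The compounds shown leave open at what concentration any of the three would reach the half-maximal read-out, and whether the group on the saturated chain carbon alters it.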